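Swapping the Indole of Compound 1 for a Bromophenyl Ring

The compounds below may be only part of what the source reports. "The series", "measured", "known", "first", "only" and "open" are said of these compounds alone.

Measured compounds:
- compound 1, `Cc1ccc(CS/C(=C/c2c[nH]c3ccc(Br)cc23)C(=O)c2ccc(Cl)cc2)cc1`: 1000 nM
- compound 2, `O=C(/C(=C\c1c[nH]c2ccc(Br)cc12)SCc1ccc(Cl)cc1Cl)c1ccc(Cl)cc1`: 10000 nM
- compound 3, `O=C(/C(=C\c1c[nH]c2ccc(Br)cc12)SCc1ccc(F)cc1)c1ccc(Cl)cc1`: 50000 nM

All three were tested in a functional assay on DU-145 cells (Homo sapiens) for inhibition, read by trypan blue exclusion, with a stated time of 96 h; a higher number here means a weaker inhibitor of growth, a lower number a stronger inhibitor of growth. Compound 1 has the lowest number of the three, so it is the strongest growth inhibitor in this set: the step of a 10-fold higher number from compound 1 to compound 2 (1.00 log units; beyond the scatter) and the step of a 50-fold higher number from compound 1 to compound 3 (1.70 log units; beyond the scatter) both lie beyond the scatter, as does the step of a 5.0-fold higher number from compound 2 to compound 3 (0.70 log units; beyond the scatter).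

The new compound 4, `Cc1ccc(CS/C(=C/c2ccccc2Br)C(=O)c2ccc(Cl)cc2)cc1`, differs from compound 1 in a different place from any measured step: 2-bromophenyl in place of 5-bromo-1H-indol-3-yl on a double-bonded chain carbon bound to a double-bonded chain carbon. Every measured step changes only the group on the saturated chain carbon bound to sulfur, while the part of compound 1 that carries the bromine and the ring nitrogen is kept throughout. Among the compounds with values here, no measured step therefore bears on this change, and the size of its effect cannot be read from the data.

Given that the whole measured series keeps this part fixed, compound 4 is expected to be a somewhat weaker inhibitor than compound 1, with wide uncertainty, by a step of a 5.0-fold higher number from compound 1 to compound 4 (0.70 log units; beyond the scatter). The estimated value for compound 4 is 5000 nM, within a range from 1000 nM to 30000 nM.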

Compound 4, concentration for 50% growth inhibition: 10000 nM
The estimate for compound 4 lay 2.0-fold (0.30 log units) below the measured number, within the range that was stated.
By their numbers in this assay, from the lowest: compound 1; then compounds 2 and 4 (each within the scatter of the next); then compound 3.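

The earlier compounds shown here all keep the 5-bromo-1H-indol-3-yl group, so they say nothing about this place, on a double-bonded chain carbon bound to a double-bonded chain carbon. In this assay, putting 2-bromophenyl there gives a 10-fold higher number from compound 1 to compound 4 (1.00 log units; beyond the scatter), which shows that growth inhibition depends on this part of the molecule as well as on the group on the saturated chain carbon bound to sulfur. The change removes a five-membered aromatic ring and the only hydrogen-bond donor in that group, but nothing here measures what lies behind the loss.

Which part of the change matters therefore stays open. A plain phenyl group or a 1H-indol-3-yl group without bromine in this place would show what the bromine contributes on each ring.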